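The source may report more compounds than this note shows. Statements on the series, on what has been measured and on what is new or still open speak of the compounds shown alone.

Measured so far:
compound 1, `Cc1nn(C)c2c1C(c1ccc3c(c1)OCCO3)C(C#N)=C(N)O2`, 8600 nM
compound 2, `Cn1nc(-c2ccccc2)c2c1OC(N)=C(C#N)C2c1ccc2c(c1)OCCO2`, 8400 nM
compound 3, `Cc1nn(C)c2c1C(c1cccnc1)C(C#N)=C(N)O2`, 8800 nM

All three were tested in a functional assay on NCI-H2122 cells (Homo sapiens) for inhibition, read by microscopy, with a stated time of 10 days; a lower number here means a stronger inhibitor, a higher number a weaker inhibitor. Compound 1 gives 8600 nM there, and compound 2 gives 8400 nM. These two differ by phenyl in place of methyl on an aromatic carbon, and the step is a 1.0-fold lower number from compound 1 to compound 2 (0.01 log units; within the scatter). Compound 3 gives 8800 nM in this assay, a number that lies close to those of compound 1 and compound 2. The difference between the core of compound 3 and the core of compound 1 is not broken down here.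

Compound 4, `Cn1nc(-c2ccccc2)c2c1OC(N)=C(C#N)C2c1cccnc1`, has not yet been measured. It relates to compound 3 by phenyl in place of methyl on an aromatic carbon, which is the same change that turns compound 1 into compound 2; the surroundings of the place are described in the same words in both cases.

Because the step of a 1.0-fold lower number from compound 1 to compound 2 (0.01 log units; within the scatter) lay within the scatter, the step from compound 3 to compound 4 is expected to be similarly small, about a 1.0-fold lower number from compound 3 to compound 4 (0.02 log units; within the scatter). Resting on that, compound 4 is estimated to give 8500 nM in this assay, with a likely range from 4300 nM to 17000 nM.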

Compound 4, half-maximal inhibitory concentration: > 10000 nM
Compound 4 was reported as a limit (the forecaster's own chance of this, stated with the estimate: 10%); middle value at least 1.1-fold (0.07 log units) from the limit.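

In this assay compound 4 is reported only as a limit, > 10000 nM. Phenyl in place of methyl on an aromatic carbon therefore gives only a floor on this second core, an at least 1.1-fold higher number from compound 3 to compound 4 (0.05 log units; that floor lies within the scatter), and the comparison with the first core stays incomplete: the same change on two cores in this assay, a 1.0-fold lower number (0.01 log units; within the scatter) from compound 1 to compound 2 and an at least 1.1-fold higher number (0.05 log units; that floor lies within the scatter) from compound 3 to compound 4; the limit leaves it open whether they differ. The two cores show no sign that the phenyl brings a lower number, but the true size of the step on the core of compound 3 cannot be read, so it is not shown that the change carries over unchanged, nor that it fails to, and the limit also restricts how far the series can be read: the limit of > 10000 nM in this assay, at which 1 of the 4 values shown sits.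

The compounds shown leave open what a longer chain, an amine or a carboxylic acid would do in place of the methyl or phenyl on that aromatic carbon. They also leave open whether any change to the shared core can give a number clearly lower than those seen here.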